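The source may hold more compounds than are shown below. What is called first, only, known or untested is meant among the compounds shown, and "the series" means these compounds.

Compound 1 `O=C1c2ccccc2C(=O)N1C/C=C\Cn1cc(C#Cc2ccc(Br)cc2)c(=O)[nH]c1=O` and compound 2 `O=C1c2ccccc2C(=O)N1C/C=C/Cn1cc(C#CCCc2ccccc2)c(=O)[nH]c1=O` share one core and were run in a functional assay on MIA PaCa-2 cells (Homo sapiens) for antiproliferative activity, read by MTT assay, with a stated time of 3 days; a higher number here means a weaker inhibitor, a lower number a stronger inhibitor. In this assay compound 2 gives 27000 nM. For compound 1, this assay reports only a limit, > 100000 nM, which is the limit of > 100000 nM in this assay, at which 1 of the 2 values shown sits; compound 1 therefore stands without a number of its own. Compound 3 `CCCCc1ccc(C#Cc2cn(C/C=C\CN3C(=O)c4ccccc4C3=O)c(=O)[nH]c2=O)cc1` differs from compound 1 by butyl in place of bromo on an aromatic carbon. Among the compounds with values here, no measured step sets the size of this change; the expected step of an at least 1.6-fold lower number from compound 1 to compound 3 (0.22 log units; that floor lies within the scatter) in this assay is modest and not clearly beyond the scatter. Compound 3 is estimated at 60000 nM, with a range from 15000 nM to 300000 nM.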

Compound 3, half-maximal inhibitory concentration: 56000 nM
Compound 3: the middle estimate sits 1.1-fold (0.03 log units) above what was measured; measured number inside the range.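

At this place on the aromatic ring, butyl in place of bromo gives, in this assay, an at least 1.7-fold lower number from compound 1 to compound 3 (0.25 log units; that floor lies within the scatter). With butyl the compound carries a number of its own, so the bulkier-named change costs nothing measurable here, but a floor within the scatter does not establish a gain. The true size of the step cannot be read because compound 1 stands at a limit: the limit of > 100000 nM in this assay, at which 1 of the 3 values shown sits.

On these data alone, whether a methyl, a longer chain such as hexyl, or an amine at this place would move the number further remains open.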